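This account rests on a few compounds, and the source may have more. Where it says the series, first, only, none or still open, it means among the compounds named here.

Measured so far:
Compound 1 `Cc1cccc([C@@H](O)C(=O)N2N=CC[C@H]2C(=O)NCc2cc(Cl)ccc2-n2cnnn2)c1`: 9.7 10^-6 cm/s
Compound 2 `O=C(NCc1cc(Cl)ccc1-n1cnnn1)[C@@H]1C[C@@H]2C[C@@H]2N1C(=O)[C@H](O)Cn1cccn1`: 0.45 10^-6 cm/s
Compound 3 `CCCC(=O)O[C@@H](C(=O)N1N=CC[C@H]1C(=O)NCc1cc(Cl)ccc1-n1cnnn1)c1ccc(F)cc1`: 25 10^-6 cm/s

All three values come from an ADME assay on Caco-2 cells (Homo sapiens) for permeability, read by LC-MS, in the apical to basolateral direction, with a stated time of 60 min, at pH 6.5; a lower number here means that the compound crosses the layer more slowly, a higher number that the compound crosses the layer faster. Compound 2 stands lowest of the three, and its gaps to compound 1 and to compound 3 both lie beyond the scatter.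

Compound 4 `CC(C)(C)C[C@@H](O)C(=O)N1[C@H](C(=O)NCc2cc(Cl)ccc2-n2cnnn2)C[C@@H]2C[C@@H]21` has not yet been measured. It departs from compound 2 in one place: tert-butyl in place of 1H-pyrazol-1-yl on a saturated chain carbon, two bonds along the chain from a carbonyl carbon and an oxygen on a saturated carbon. The change puts tert-butyl in place of 1H-pyrazol-1-yl on a saturated chain carbon, two bonds along the chain from a carbonyl carbon and an oxygen on a saturated carbon.

Within the data shown here, no measured pair shows this change on its own, and no other measured compound shares the core of compound 2, so any expectation here is rough. Among the measured compounds shown here, the only guide is a comparison of unlike compounds. For the measured compounds named here, compound 2, the one measured compound carrying 1H-pyrazol-1-yl, gives 0.45 10^-6 cm/s, whereas compound 1, without that group, gives 9.7 10^-6 cm/s. Compound 3, also without it, gives 25 10^-6 cm/s. Both of these differ from compound 2 elsewhere too.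

On that basis, the expected change is a rise beyond the scatter, estimated as a 13-fold higher number from compound 2 to compound 4 (1.12 log units; beyond the scatter). Compound 4 is expected at about 6 10^-6 cm/s, with an estimated range from 1.5 10^-6 cm/s to 20 10^-6 cm/s.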

Compound 4, apparent permeability: 25 10^-6 cm/s
Compound 4: middle estimate off by 4.2-fold (0.62 log units), on the low side; the whole stated range lies below it.
By their numbers in this assay, from the lowest: compound 2; then compound 1; then compounds 3 and 4 (each within the scatter of the next).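

In this assay, among these compounds, this is the first comparison in which the group on the saturated chain carbon, two bonds along the chain from a carbonyl carbon and an oxygen on a saturated carbon, changes while the rest of the molecule stays the same. Among the compounds shown here, putting tert-butyl in place of 1H-pyrazol-1-yl gives a 56-fold higher number from compound 2 to compound 4 (1.74 log units; beyond the scatter) and so shows that this one place alone can move the read-out by a large margin, which the earlier compounds, differing in more than one place, could not show. The change removes a five-membered aromatic ring with two nitrogen atoms and brings in four carbon atoms without a ring, but no measurement here explains why the number rises.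

For the compounds shown here, the single step does not separate the loss of the ring from the loss of the two nitrogen atoms, and a phenyl group at this place, a ring of carbon only, or an amine on the same chain would bear on that question. On these data alone, it also remains open whether tert-butyl in place of 1H-pyrazol-1-yl would give a step of similar size on the core of compound 1.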